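The source may hold more compounds than are shown below. What is called first, only, known or untested is meant among the compounds shown, and "the series" means these compounds.

Measured in a functional assay on SGC-7901 cells (Homo sapiens) for antiproliferative activity, read by MTT assay, with a stated time of 72 h; on this read-out higher numbers stand for weaker inhibition and lower numbers for stronger inhibition:
- Compound 1 `COc1ccc(-c2c(-c3cc(OC)c(OC)c(OC)c3)ssc2=O)cc1`: > 100000 nM
- Compound 2 `COc1ccc(-c2c(-c3cc(OC)c(OC)c(OC)c3)ssc2=O)cc1[N+](=O)[O-]`: > 100000 nM

Compound 1 gives > 100000 nM, which is a limit of the assay and not a number. Compound 2 also gives only a limit, > 100000 nM. Both values sit at the same edge: the limit of > 100000 nM in this assay, at which 2 of the 2 values shown sit. For the measured compounds named here, compound 2 therefore has no exact place on the scale, and the only measured step, a step that the two limits leave unreadable from compound 1 to compound 2, has no readable size.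

Compound 3 `COc1ccc(-c2c(-c3cc(OC)c(OC)c(OC)c3)ssc2=O)cc1N` keeps the shared core and changes one group: amino in place of nitro on an aromatic carbon. It carries amino in place of nitro on an aromatic carbon, ortho to a methoxy group. Going by the values given here, with compound 2 known only as > 100000 nM, there is no measured step to scale from, so only a modest gain toward stronger inhibition is expected, and another limit is quite possible. The expected change is an at least 2.0-fold lower number from compound 2 to compound 3 (0.30 log units; that floor lies within the scatter). For compound 3 the estimate is 50000 nM, with an expected range of 3000 nM to 100000 nM.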

Compound 3, half-maximal inhibitory concentration: > 100000 nM
Compound 3 was reported as a limit; the forecaster's own chance of this, stated with the estimate: 55%; middle value at least 2.0-fold (0.30 log units) from the limit.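

For the compounds shown here, compound 3 also gives only a limit, so no step among compound 1, compound 2 and compound 3 can be read: the limit of > 100000 nM in this assay, at which 3 of the 3 values shown sit.

The compounds shown leave open whether any change to the shared core gives a measurable value in this assay.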